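Carbamoyl in place of the sulfur-bearing group: series notes

The source may report more compounds than this note shows. Statements on the series, on what has been measured and on what is new or still open speak of the compounds shown alone.

Measured so far:
Compound 1 `CC(C)(C)c1ccc(Cn2cc(C(N)=O)c3c(N)ncnc32)cc1`: in a functional assay on KB cells (Homo sapiens) for cytotoxicity (on this read-out higher numbers stand for weaker inhibition and lower numbers for stronger inhibition), compound 1 gives 900 nM.
Compound 2 `CC(C)(C)c1ccc(Cn2cc(C(=N)S)c3c(N)ncnc32)cc1`: in this assay compound 2 gives 7000 nM.
Compound 3 `Cc1ccccc1Cn1cc(C(=N)S)c2c(N)ncnc21`: in this assay compound 3 reaches only a limit of the assay, > 17000 nM.

Compound 4 `Cc1ccccc1Cn1cc(C(N)=O)c2c(N)ncnc21` has not yet been measured in this assay. The change from compound 2 to compound 1 is a group of 3 heavy atoms (1 carbon, 1 nitrogen, 1 oxygen; no ring) in place of a group of 3 heavy atoms (1 carbon, 1 nitrogen, 1 sulfur; no ring), on an aromatic carbon, and the step it made was a 7.8-fold lower number from compound 2 to compound 1 (0.89 log units; beyond the scatter). The same kind of change leads from compound 3 to compound 4: a group of 3 heavy atoms (1 carbon, 1 nitrogen, 1 oxygen; no ring) in place of a group of 3 heavy atoms (1 carbon, 1 nitrogen, 1 sulfur; no ring), on an aromatic carbon. The two places agree except in how the ring atom carrying the larger substituent is described, so the change is the same kind of change, not the same. Among the compounds with values here, how the core of compound 3 differs from that of compound 2 is not broken down here; their values show only that compound 2 gives a number where compound 3 reaches a limit. Compound 3 stands at the limit of > 17000 nM in this assay, at which 1 of the 3 values shown sits, so the starting point for compound 4 is known only as a limit, and any step from it is uncertain.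

A step in the same direction is expected from compound 3 to compound 4, an at least 2.1-fold lower number from compound 3 to compound 4 (0.32 log units; beyond the scatter), resting on a 7.8-fold lower number from compound 2 to compound 1 (0.89 log units; beyond the scatter). Compound 4 is expected to give about 8000 nM in this assay, with a likely range from 2500 nM to 30000 nM, and a fair chance that only a limit is reported.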

Compound 4, half-maximal inhibitory concentration: > 100000 nM
Compound 4 gave a limit, no number; the forecaster's own chance of this, stated with the estimate: 30%; at least 12-fold (1.09 log units) between middle value and limit.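

In this assay compound 3 gives > 17000 nM, a limit of the assay and not a number. Compound 4 gives > 100000 nM, likewise a limit. Within the data shown here, with both values at limits, no step from compound 3 to compound 4 can be read. The compounds shown leave open whether carbamoyl on the core of compound 3 moves the number in the same direction as a 7.8-fold lower number from compound 2 to compound 1 (0.89 log units; beyond the scatter).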